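Shortening the Aryl Alkyl Chain by One Carbon

The source may report more compounds than this note shows. Statements on the series, on what has been measured and on what is new or still open speak of the compounds shown alone.

Compound 3 `CCCCCc1ccc(C#Cc2cn(C/C=C/CN3C(=O)c4ccccc4C3=O)c(=O)[nH]c2=O)cc1` has the lowest of the three numbers recorded in a functional assay on MCF7 cells (Homo sapiens) for antiproliferative activity, read by MTT assay, with a stated time of 3 days (on this read-out higher numbers stand for weaker inhibition and lower numbers for stronger inhibition), where compound 3 gives 5600 nM. Its nearest neighbour is compound 1 `CCCCC#Cc1cn(C/C=C/CN2C(=O)c3ccccc3C2=O)c(=O)[nH]c1=O`, which in this assay gives 8800 nM, a gap within the scatter, so no order can be read between these two. The furthest is compound 2 `O=C1c2ccccc2C(=O)N1C/C=C/Cn1cc(C#CCCc2ccccc2)c(=O)[nH]c1=O`, which in this assay gives 13000 nM; the step of a 2.3-fold lower number from compound 2 to compound 3 (0.37 log units; beyond the scatter) is the only one beyond the scatter among the three. The remaining steps, a 1.5-fold higher number from compound 1 to compound 2 (0.17 log units; within the scatter) and a 1.6-fold lower number from compound 1 to compound 3 (0.20 log units; within the scatter), are within the scatter.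

Compound 4 `CCCCc1ccc(C#Cc2cn(C/C=C/CN3C(=O)c4ccccc4C3=O)c(=O)[nH]c2=O)cc1` differs from compound 3 by hydrogen in place of methyl on a saturated chain carbon, four bonds along the chain from an aromatic carbon. Going by the values given here, none of the measured steps removes a single chain carbon in this way; all three exchange whole substituents on or near the triple-bonded carbon, and all are small. Among the compounds with values here, with no direct precedent, the step of a 1.1-fold higher number from compound 3 to compound 4 (0.03 log units; within the scatter) is expected to stay within the scatter. Compound 4 is therefore estimated to give 6000 nM in this assay, with a range from 3000 nM to 12000 nM.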

Compound 4, half-maximal inhibitory concentration: 44000 nM
Compound 4: middle estimate off by 7.3-fold (0.87 log units), on the low side; the whole stated range lies below it.
By their numbers in this assay, from the lowest: compounds 3, 1 and 2 (each within the scatter of the next, the first and the last beyond it); then compound 4.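

In this assay, taking one methyl off the end of the 4-pentylphenyl chain, at the place four bonds along the chain from an aromatic carbon, gives the largest step seen so far (a 7.9-fold higher number from compound 3 to compound 4 (0.90 log units; beyond the scatter)), so this position responds to the loss of a single carbon, whereas two of the three earlier exchanges of whole substituents stayed within the scatter. Compound 4 also separates from the other two compounds (a 3.4-fold higher number from compound 2 to compound 4 (0.53 log units; beyond the scatter); a 5.0-fold higher number from compound 1 to compound 4 (0.70 log units; beyond the scatter)), while 4-pentylphenyl in compound 3 stays within the scatter of butyl in compound 1, so among these compounds an aryl group on the triple-bonded carbon does not by itself set the number. Nothing at hand accounts for this step.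

The compounds shown leave open how a 4-propylphenyl or 4-hexylphenyl group would read, and so whether the number follows chain length in any regular way. They also leave open whether an amine or a carboxylic acid at the chain end would be tolerated.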